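Adding a second chloro to compound 2

The source may report more compounds than this note shows. Statements on the series, on what has been measured and on what is new or still open speak of the compounds shown alone.

Going by the values given here, the series so far holds compound 1 `CCN(CC)CCCS(=O)(=O)c1ccc2nc(NC(=O)NC(=O)c3cc(-n4cccn4)ccc3Cl)sc2c1` and compound 2 `CN1CCN(CCCS(=O)(=O)c2ccc3nc(NC(=O)NC(=O)c4cc(-n5cccn5)ccc4Cl)sc3c2)CC1`. In an assay on HEK293 cells for displacement of a labelled ligand from growth hormone secretagogue receptor type 1 (Homo sapiens), with a stated time of 60 min (a higher number here means a weaker inhibitor, a lower number a stronger inhibitor), compound 1 gives 3.9 nM, and compound 2 gives 0.67 nM. Among the compounds with values here, the only measured step, a 5.8-fold lower number from compound 1 to compound 2 (0.76 log units; beyond the scatter), concerns the amine at the end of the chain. On the numbers shown compound 2 stands lowest, with compound 1 the nearest. Compound 3 `CN1CCN(CCCS(=O)(=O)c2ccc3nc(NC(=O)NC(=O)c4cc(-n5cccn5)c(Cl)cc4Cl)sc3c2)CC1` differs from compound 2 by chloro in place of hydrogen on an aromatic carbon. Within the data shown here, no measured step bears on this change, so it is untested. The expected step of a 1.0-fold higher number from compound 2 to compound 3 (0.02 log units; within the scatter) is none beyond the scatter. Compound 3 is therefore expected to give 0.7 nM in this assay, within 0.25 nM to 2 nM.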

Compound 3, half-maximal inhibitory concentration: 0.31 nM
Beside the measured number, compound 3's estimate is 2.3-fold (0.35 log units) above it, and the stated range covers the measured number.
By their numbers in this assay, from the lowest: compound 3; then compound 2; then compound 1.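

In this assay, chloro in place of hydrogen on the aromatic carbon ortho to the 1H-pyrazol-1-yl group gives a 2.2-fold lower number from compound 2 to compound 3 (0.33 log units; beyond the scatter), so this carbon takes a second chloro and the number falls further. Going by these compounds alone, this is the first reading of a change on this ring, as the earlier step concerned only the amine at the chain end. No measurement at hand accounts for this step.

On these data alone, whether fluoro, methyl or methoxy on this carbon would read like chloro remains open. Also open, as far as these compounds go, is whether the step carries over with diethylamino at the chain end.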